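Replacing a Trifluoromethyl Group with a Carboxy Group

This account rests on a few compounds, and the source may have more. Where it says the series, first, only, none or still open, it means among the compounds named here.

Of the compounds shown here, three sharing one core have been tested in an assay on isolated protein for inhibition of 2-Hydroxyacid oxidase 2 (Rattus norvegicus), tested at 1 uM; a lower number here means a weaker effect, a higher number a stronger effect of the compound at the concentration tested. Compound 1 `Cc1n[nH]c(C(=O)O)c1Cc1ccc(C(F)(F)F)cc1` gives 35%, the highest of the three numbers. Compound 2 `Cc1n[nH]c(C(=O)O)c1Cc1ccccc1-c1ccc(F)cc1` gives 21%, a weaker effect that lies beyond the usual scatter of this assay. Compound 3 `Cc1n[nH]c(C(=O)NS(C)(=O)=O)c1Cc1cccc(-c2ccc(F)cc2)c1` gives 0%, the lowest of the three and further still from compound 1. Compound 1 is thus the strongest of the measured set.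

The next compound, compound 4 `Cc1n[nH]c(C(=O)O)c1Cc1ccc(C(=O)O)cc1`, has not yet been measured. It differs from compound 1 in one place: carboxy in place of trifluoromethyl on an aromatic carbon. The carboxy group brings a hydrogen-bond donor and acceptor where the trifluoromethyl group had none. Among the compounds with values here, no measured pair shows the effect of such a swap, so the expectation rests only on the spread seen so far, in which every change away from compound 1 has lowered the number. A modest decrease is expected, a number 13 percentage points lower from compound 1 to compound 4 (beyond the scatter), near the edge of the scatter. Compound 4 is therefore estimated at 22%, with a range from 0% to 45%.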

Compound 4, a percentage reported as inhibition, at one concentration (the size of the read-out at that concentration, not a potency): 40%
Compound 4: the middle estimate sits 18 percentage points below what was measured; measured number inside the range.
By their numbers in this assay, from the lowest: compound 3; then compound 2; then compounds 1 and 4 (each within the scatter of the next).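

In this assay the swap of trifluoromethyl for carboxy on this aromatic carbon gives a number 5 percentage points higher from compound 1 to compound 4 (within the scatter) and so the two groups cannot be told apart at this position. The position thus accepts a group with a hydrogen-bond donor and a hydrogen-bond acceptor in place of one with neither, without a change that this read-out can detect. Nothing available explains why two such different groups give matching numbers.

Still open, on these data alone, is whether this tolerance extends to other groups on the same carbon, such as an amine, a methyl ester or a plain hydrogen, any of which would test how much the group there matters at all. As far as these compounds go, the read-out also comes from a single concentration, so any difference in potency between the two compounds remains unknown.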